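A few compounds are considered here, and "the series" means these few. Any claim that something is new, unique, unknown or untested is made for them only; others in the source may bear on it.

Three compounds have so far been measured in a functional assay on COLO 205 cells (Homo sapiens) for inhibition, read by sulforhodamine B assay, with a stated time of 48 h; a higher number here means a weaker inhibitor of growth, a lower number a stronger inhibitor of growth:

Compound 1 `Nc1cc(N)c2nc(-c3ccccc3)c(Oc3ccc(Cl)c(Cl)c3)nc2c1` gives 20400 nM.
Compound 2 `CCOC(=O)[C@H](CCC(=O)O)NC(=O)c1ccc(Sc2nc3cc(N)cc(N)c3nc2-c2ccccc2)cc1` gives 28200 nM.
Compound 3 `COc1cc(CNc2nc3cc(N)cc(N)c3nc2-c2ccccc2)cc(OC)c1OC` gives 3800 nM.

Among these numbers compound 1 stands second highest of the three. Its nearest neighbour is compound 2, whose value lies within the usual scatter of compound 1, so the two cannot be told apart on this evidence. Compound 3 is the furthest away, with a lower number that lies beyond the scatter, so of the three it is the one that inhibits growth most strongly.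

The next compound to be considered, compound 4 `Nc1cc(N)c2nc(-c3ccccc3)c(Sc3ccc(Cl)c(Cl)c3)nc2c1`, keeps the shared core of compound 1 and its phenyl group and differs from compound 1 in a single place: (3,4-dichlorophenyl)sulfanyl in place of 3,4-dichlorophenoxy on an aromatic carbon. Within the data shown here, no measured pair in this set carries exactly this change, so its effect in this assay is not yet known from a matched comparison. Among the measured compounds shown here, the only other compound with a sulfur linker, compound 2, gives a number close to that of compound 1, but it carries a quite different group on that sulfur, so it offers little guidance. With nothing to point either way, the step from compound 1 to compound 4 is expected to be small, a 1.0-fold lower number from compound 1 to compound 4 (0.01 log units; within the scatter), and not beyond the scatter in either direction. Compound 4 is therefore estimated at 20000 nM, with a range from 8000 nM to 50000 nM.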

Compound 4, concentration for 50% growth inhibition: 10700 nM
Beside the measured number, compound 4's estimate is 1.9-fold (0.27 log units) above it, and the stated range covers the measured number.
By their numbers in this assay, from the lowest: compound 3; then compounds 4, 1 and 2 (each within the scatter of the next, the first and the last beyond it).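

In this assay, among these compounds, this is the first matched comparison at this position, on an aromatic carbon next to the ring nitrogen, and (3,4-dichlorophenyl)sulfanyl in place of 3,4-dichlorophenoxy gives a 1.9-fold lower number from compound 1 to compound 4 (0.28 log units; within the scatter). With the shared core, the phenyl group and the dichlorinated ring all held constant, sulfur and oxygen as the linking atom cannot be told apart on this evidence. Nothing shown here accounts for how closely the two compounds read.

The compounds shown leave open whether a sulfonyl link at this position, carrying the same dichlorinated ring, would also read like the oxygen and sulfur links. They also leave open whether fluorine in place of the two chlorine atoms would alter growth inhibition with either link.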